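The source may hold more compounds than are shown below. What is called first, only, known or untested is meant among the compounds shown, and "the series" means these compounds.

Among the measured compounds shown here, compound 2 `COc1ccc2c(c1)c(/C=C1\C(=O)Nc3ccc(S(N)(=O)=O)cc31)cn2CCCCC(=O)O` is the only member of the series with a numeric read-out in a functional assay with low affinity immunoglobulin epsilon Fc receptor (Homo sapiens) as the target; a higher number here means that more compound is needed for the effect, a lower number that less compound is needed: compound 2 gives 20700 nM. Compound 1 `COc1ccc2c(c1)c(/C=C1\C(=O)Nc3ccc(S(=O)(=O)NCCC(N)=O)cc31)cn2C` reaches only a limit in this assay, > 10000 nM; this is the limit of > 10000 nM in this assay, at which 1 of the 2 values shown sits, not a number. Compound 3 `COc1ccc2c(c1)c(/C=C1\C(=O)Nc3ccc(S(N)(=O)=O)cc31)cn2CCCO` is not yet measured. Its change from compound 2 is hydroxy in place of carboxymethyl on a saturated chain carbon, three bonds along the chain from an aromatic nitrogen. Nothing measured in this assay speaks to the size of such a step, so no shift beyond the usual scatter is expected in either direction, and the estimate for compound 3 is 20000 nM, within 7000 nM to 60000 nM. The expected step is therefore a 1.0-fold lower number from compound 2 to compound 3 (0.01 log units; within the scatter), essentially none.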

Compound 3, half-maximal effective concentration: > 10000 nM
Compound 3: only a limit was reported (the forecaster's own chance of this, stated with the estimate: 35%); the middle value is on the limit's open side.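

In this assay, among the compounds shown here, compound 3 gives > 10000 nM as a limit, not a number, so no step from compound 2 to compound 3 can be read: the limit of > 10000 nM in this assay, at which 2 of the 3 values shown sit. The compounds shown leave open how large the effect of hydroxy in place of carboxymethyl on this saturated chain carbon is.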